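A Methoxy-to-Methyl Swap on an Oxalamide Series

The compounds below may be only part of what the source reports. "The series", "measured", "known", "first", "only" and "open" are said of these compounds alone.

Measured so far:
compound 1, `O=C(Nc1ccc(O)cc1)C(=O)Nc1ccc2c(c1)COC2=O`, 5030 nM in a functional assay on cells (T-cell, Mus musculus) for inhibition; a higher number here means a weaker inhibitor, a lower number a stronger inhibitor
compound 2, `COc1ccc(NC(=O)C(=O)Nc2ccc3c(c2)COC3=O)cc1`, 153000 nM

Among the measured compounds shown here, compound 2 stands at the highest of the two numbers so far, with compound 1 as its only neighbour at a far lower value; the one step that separates them, a 30-fold higher number from compound 1 to compound 2 (1.48 log units; beyond the scatter), is large and well beyond the scatter. The next compound, compound 3, has the structure `Cc1ccccc1NC(=O)C(=O)Nc1ccc2c(c1)COC2=O`. The change that leads from compound 2 to compound 3 is 2-methylphenyl in place of 4-methoxyphenyl on an amide-type nitrogen. For the measured compounds named here, no measured step concerns this exact exchange. Going by the values given here, the only step available, the one from compound 1 to compound 2, touches the same ring and shows that altering the group on that ring can move the number a great deal, but it does not say in which direction the present change will go. He therefore expects a step of uncertain direction and a wide range for compound 3, estimated at 40000 nM within 6000 nM to 200000 nM, corresponding to an expected step of a 3.8-fold lower number from compound 2 to compound 3 (0.58 log units; beyond the scatter) from compound 2.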

Compound 3, half-maximal inhibitory concentration: 5510 nM
Beside the measured number, compound 3's estimate is 7.3-fold (0.86 log units) above it; measured number below the stated range.
By their numbers in this assay, from the lowest: compounds 1 and 3 (each within the scatter of the next); then compound 2.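

In this assay, the exchange of 4-methoxyphenyl for 2-methylphenyl on the amide-type nitrogen gives a 28-fold lower number from compound 2 to compound 3 (1.44 log units; beyond the scatter), so this position can also return a large step when the whole aryl group is exchanged, not only when a methyl replaces a hydrogen on the ring oxygen. The comparison with compound 1 gives a 1.1-fold higher number from compound 1 to compound 3 (0.04 log units; within the scatter), which lies within the scatter, so 4-hydroxyphenyl and 2-methylphenyl cannot be told apart here even though only the former carries a hydrogen-bond donor. Among these three groups, 4-methoxyphenyl alone stands apart, and compound 2 is the weakest inhibitor of the three, with its steps to both other compounds beyond the scatter.

Nothing in the data shown accounts for the size of these steps. The exchange from compound 2 to compound 3 alters both the group on the ring and its place there, so the compounds leave open which of these carries the step, and also how an amine or a carboxylic acid on this ring would compare.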